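The source may report more compounds than this note shows. Statements on the series, on what has been measured and on what is new or still open speak of the compounds shown alone.

Measured so far in a functional assay on PC-3 cells (Homo sapiens) for cytotoxicity, read by MTT assay, with a stated time of 72 h; a lower number here means a stronger inhibitor of growth, a higher number a weaker inhibitor of growth:
- compound 2 `N#C[Se]c1ccc(NC(=O)OCc2ccc([N+](=O)[O-])cc2)cc1`: 9000 nM
- compound 1 `CCCOC(=O)Nc1ccc([Se]C#N)cc1`: 21100 nM

Compound 2 has the lowest of the two numbers in this assay; the nearest is compound 1, whose number is higher by a margin beyond the scatter. Both share the same core, differing only in the carbamate ester portion.

The next compound, compound 3 `N#C[Se]c1ccc(NC(=O)OCc2ccccc2)cc1`, differs from compound 2 by hydrogen in place of nitro on an aromatic carbon. Among the compounds with values here, no pair among the measured compounds isolates this change, so its size is not known from the data. The expectation is a small step, if any, toward a higher number, probably within the scatter of repeated measurements. Compound 3 is accordingly expected to give 12000 nM in this assay, with a range from 4500 nM to 32000 nM; the expected step is a 1.3-fold higher number from compound 2 to compound 3 (0.12 log units; within the scatter).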

Compound 3, concentration for 50% growth inhibition: 3700 nM
Compound 3: middle estimate off by 3.2-fold (0.51 log units), on the high side; the whole stated range lies above it.
By their numbers in this assay, from the lowest: compound 3; then compound 2; then compound 1.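

In this assay, hydrogen in place of nitro on the aromatic carbon gives a 2.4-fold lower number from compound 2 to compound 3 (0.39 log units; beyond the scatter), so nitro at this place is not needed for growth inhibition, and the unsubstituted ring gives the lower number. Phenyl in place of ethyl on the saturated chain carbon bound to the oxygen next to the carbonyl group gives a 5.7-fold lower number from compound 1 to compound 3 (0.76 log units; beyond the scatter), which shows that an aromatic ring at this end of the carbamate already lowers the number without any substituent on it. Nothing available explains either step.

Still open, as far as these compounds go, is whether another group at the same aromatic carbon, such as an amine or a methoxy group, would lower or raise the number relative to hydrogen. Also open, from the compounds shown here alone, is how a longer chain between the oxygen and the phenyl would compare.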